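From bromo to fluoro in a cytotoxic pair

A few compounds are considered here, and "the series" means these few. Any claim that something is new, unique, unknown or untested is made for them only; others in the source may bear on it.

Compound 1 `O=S(=O)(c1ccc(F)cc1)c1nc2ccccc2nc1N1CCc2ccccc2C1` – 22900 nM
Compound 2 `O=S(=O)(c1ccc(Br)cc1)c1nc2ccccc2nc1N1CCCC(O)C1` – 2100 nM

In a functional assay on A549 cells (Homo sapiens) for cytotoxicity, read by MTT assay, with a stated time of 72 h (on this read-out lower numbers stand for stronger inhibition and higher numbers for weaker inhibition), compound 2 has the lower of the two numbers (2100 nM) and stands beyond the scatter from compound 1. Compound 3 `O=S(=O)(c1ccc(F)cc1)c1nc2ccccc2nc1N1CCCC(O)C1` differs from compound 2 in one place (fluoro in place of bromo on an aromatic carbon): fluoro in place of bromo on an aromatic carbon. Within the data shown here, no measured pair shows this change alone. Compound 1 also carries fluoro and reads higher (22900 nM), but it differs elsewhere too, so this is weak evidence. A modest rise is expected (a 1.9-fold higher number from compound 2 to compound 3 (0.28 log units; within the scatter)). For compound 3 the estimate is 4000 nM (expected range 1300 nM to 12000 nM).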

Compound 3, half-maximal inhibitory concentration: 8170 nM
Compound 3: middle estimate off by 2.0-fold (0.31 log units), on the low side; low and high end bracket the measured number.
By their numbers in this assay, from the lowest: compound 2; then compound 3; then compound 1.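

In this assay, the change from 4-bromophenyl to 4-fluorophenyl, with nothing else altered, gives a 3.9-fold higher number from compound 2 to compound 3 (0.59 log units; beyond the scatter), so this position responds to the halogen, which the first two compounds, differing in more than one place, could not show. With fluoro held constant, 3-hydroxypiperidin-1-yl in place of 1,2,3,4-tetrahydroisoquinolin-2-yl gives a 2.8-fold lower number from compound 1 to compound 3 (0.45 log units; beyond the scatter), so both sites affect the number. Nothing measured here explains either step. On these data alone, whether chloro or methyl at this aromatic carbon would fall between bromo and fluoro remains open.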